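A few compounds are considered here, and "the series" means these few. Any claim that something is new, unique, unknown or untested is made for them only; others in the source may bear on it.

Working notes on the series.

The three measured compounds share one core and differ only in the aryl group on the amide-type nitrogen. Compound 1 `CN(C)C(=O)c1cc2cnc(Nc3ccc(NC(=O)C4(C(=O)Nc5cccc(F)c5)CC4)cc3)nc2n1C1CCCC1` gives -0.4% in a functional assay on T47D cells (Homo sapiens) for inhibition, read by CCK-8 assay, with a stated time of 72 h, tested at 10 uM; on this read-out lower numbers stand for less inhibition of growth and higher numbers for more inhibition of growth at the one concentration tested. Compound 2 `CN(C)C(=O)c1cc2cnc(Nc3ccc(NC(=O)C4(C(=O)Nc5cccc(O)c5)CC4)cc3)nc2n1C1CCCC1` gives 83.7% in this assay, and compound 3 `CN(C)C(=O)c1cc2cnc(Nc3ccc(NC(=O)C4(C(=O)Nc5ccccc5F)CC4)cc3)nc2n1C1CCCC1` gives 97.8% in this assay. Compound 3 thus stands highest of the three numbers; the gap to compound 2 is beyond the scatter, as is the much larger gap to compound 1.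

The steps measured so far are a number 84.1 percentage points higher from compound 1 to compound 2 (beyond the scatter), a number 98.2 percentage points higher from compound 1 to compound 3 (beyond the scatter) and a number 14.1 percentage points higher from compound 2 to compound 3 (beyond the scatter). All three concern the same aryl group, and each is beyond the scatter, so the read-out responds strongly to what sits on this nitrogen.

Compound 4 `CN(C)C(=O)c1cc2cnc(Nc3ccc(NC(=O)C4(C(=O)Nc5ccc(Cl)c(C(F)(F)F)c5)CC4)cc3)nc2n1C1CCCC1` differs from compound 3 by 4-chloro-3-(trifluoromethyl)phenyl in place of 2-fluorophenyl on an amide-type nitrogen. Among the compounds with values here, no measured step puts a chloro or trifluoromethyl group on this ring, so none bears directly on the change. Since compound 3 already gives 97.8%, the room upward is small, and the large steps seen elsewhere make a downward move plausible. The expected step is a number 27.8 percentage points lower from compound 3 to compound 4 (beyond the scatter), with wide uncertainty. For compound 4 the estimate in this assay is 70%, within 20% to 100%.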

Compound 4, percent growth inhibition at one concentration: 55.8%
Compound 4: the middle estimate sits 14.2 percentage points above what was measured, within the range that was stated.
By their numbers in this assay, from the lowest: compound 1; then compound 4; then compound 2; then compound 3.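

The 4-chloro-3-(trifluoromethyl)phenyl group on the amide-type nitrogen, with 11 heavy atoms against 7 for 2-fluorophenyl, leaves a substantial read-out in this assay and gives a number 42 percentage points lower from compound 3 to compound 4 (beyond the scatter) and a number 27.9 percentage points lower from compound 2 to compound 4 (beyond the scatter) but also a number 56.2 percentage points higher from compound 1 to compound 4 (beyond the scatter), so compound 4 ranks above compound 1 and under compound 2 and compound 3. The larger group therefore does not abolish growth inhibition at this position, and the size of the aryl group alone does not order the four compounds: compound 1 and compound 3 both carry a fluorophenyl group, yet they stand lowest and highest. No supporting measurement is at hand to explain these steps.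

Going by these compounds, the chloro and trifluoromethyl groups enter together, so the share of each in the step remains open, as does whether either alone on the ring would stay closer to compound 3. On these data alone, it is also open whether an amine or a carboxylic acid on this ring would follow the hydroxy group of compound 2, and whether a benzyl group on this nitrogen would keep the read-out.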